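From 2-cyanocyclopropyl to 3-cyanocyclobutyl

The source may hold more compounds than are shown below. What is called first, only, known or untested is meant among the compounds shown, and "the series" means these compounds.

In an ADME assay on MDCKII-LE cells (Canis lupus familiaris) for permeability (on this read-out lower numbers stand for lower permeability and higher numbers for higher permeability), compound 1 `N#CCCN([C@H](CCC(F)(F)F)C(N)=O)S(=O)(=O)c1ccc(Cl)cc1` gives 10.2 10^-6 cm/s, compound 2 `N#CCCCCN([C@H](CCC(F)(F)F)C(N)=O)S(=O)(=O)c1ccc(Cl)cc1` gives 24 10^-6 cm/s and compound 3 `N#C[C@@H]1C[C@H]1CN([C@H](CCC(F)(F)F)C(N)=O)S(=O)(=O)c1ccc(Cl)cc1` gives 9.94 10^-6 cm/s. Compound 3 therefore stands level with compound 1 and under compound 2, the latter gap being a 2.4-fold lower number from compound 2 to compound 3 (0.38 log units; beyond the scatter).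

Compound 4 `N#C[C@H]1C[C@@H](CN([C@H](CCC(F)(F)F)C(N)=O)S(=O)(=O)c2ccc(Cl)cc2)C1` carries 3-cyanocyclobutyl in place of 2-cyanocyclopropyl on a saturated chain carbon bound to a sulfonamide nitrogen.

Within the data shown here, no measured step exchanges one ring for another, so the evidence is indirect. Among the measured compounds shown here, two steps bear on the change. The cyclopropyl-bearing compound 3 shows no separation from its open-chain partner, with a 1.0-fold lower number from compound 1 to compound 3 (0.01 log units; within the scatter). Chain extension gave a 2.4-fold higher number from compound 1 to compound 2 (0.37 log units; beyond the scatter), the only measured rise in the set. Together these suggest a small upward move at most, and a step beyond the scatter is not expected. The expected step in this assay is a 1.3-fold higher number from compound 3 to compound 4 (0.12 log units; within the scatter). The value for compound 4 is estimated at 13 10^-6 cm/s, with an expected range of 7 10^-6 cm/s to 24 10^-6 cm/s.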

Compound 4, apparent permeability: 24.1 10^-6 cm/s
Compound 4: middle estimate off by 1.9-fold (0.27 log units), on the low side, outside the stated range (above it).
By their numbers in this assay, from the lowest: compounds 3 and 1 (each within the scatter of the next); then compounds 2 and 4 (each within the scatter of the next).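

In this assay, the change of ring at this position, on a saturated chain carbon bound to a sulfonamide nitrogen, gives a step beyond the scatter (a 2.4-fold higher number from compound 3 to compound 4 (0.38 log units; beyond the scatter)), whereas the earlier cyclopropyl-bearing compound 3 had shown no separation from the open-chain compound 1. The 3-cyanocyclobutyl group also separates from cyanomethyl (a 2.4-fold higher number from compound 1 to compound 4 (0.37 log units; beyond the scatter)) and stands level with 3-cyanopropyl (a 1.0-fold higher number from compound 2 to compound 4 (0.00 log units; within the scatter)), so in this small set a ring-bearing compound reaches the number of the longest open chain. No measured evidence here bears on the reason for these steps.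

Still open, from the compounds shown here alone, is whether the step follows ring size alone or also the place of the nitrile on the ring, since the two rings differ in both. Going by these compounds, it is also open how the number responds when a carboxylic acid or an amine stands in place of the nitrile on the 3-cyanocyclobutyl ring.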